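Removing the aryl methyl: compound 3 to compound 4

The source may hold more compounds than are shown below. What is called first, only, known or untested is meant among the compounds shown, and "the series" means these compounds.

Measured so far in a functional assay on the whole organism (strain albino) with Mus musculus as the target, in the maximal electroshock model, with a stated time of 0.5 h; on this read-out higher numbers stand for an effect only at larger amounts of compound and lower numbers for an effect already at smaller amounts:
compound 1 `Cc1ccccc1Nc1nnc(Nc2nc(-c3ccc(Cl)cc3)cs2)s1` gives 300 mg/kg
compound 2 `COc1ccc(Nc2nnc(Nc3nc(-c4ccc(Cl)cc4)cs3)s2)cc1` gives 100 mg/kg
compound 3 `Cc1ccc(Nc2nnc(Nc3nc(-c4ccc(Br)cc4)cs3)s2)cc1` gives 100 mg/kg

Among the compounds with values here, compound 3 stands level with compound 2 at the digits recorded, the two together the lowest numbers of the three; compound 1 sits above both, and the only single-point step measured, a 3.0-fold lower number from compound 1 to compound 2 (0.48 log units; beyond the scatter), is a modest one beyond the scatter.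

Compound 4 `Brc1ccc(-c2csc(Nc3nnc(Nc4ccccc4)s3)n2)cc1` differs from compound 3 in one place: hydrogen in place of methyl on an aromatic carbon. Cut one bond further out, 4-methylphenyl becomes phenyl and the (4-methylphenyl)amino group becomes anilino. Within the data shown here, no measured pair isolates this change. Among the measured compounds shown here, the one step available, a 3.0-fold lower number from compound 1 to compound 2 (0.48 log units; beyond the scatter), swaps both the group and its place on the ring at once, so it bears on compound 4 only loosely; it shows that the aryl on the nitrogen can move the minimum effective dose by a modest amount, and nothing shows that loss of the methyl alone would do more. The expectation is therefore a step of about no change at the digits printed from compound 3 to compound 4 (within the scatter), within the scatter, with the larger uncertainty toward higher numbers. Compound 4 is estimated at 100 mg/kg, range 50 mg/kg to 300 mg/kg.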

Compound 4, minimum effective dose: 300 mg/kg
For compound 4 the middle estimate is 3.0-fold (0.48 log units) below the measured one; the measured number falls inside the stated range.
By their numbers in this assay, from the lowest: compounds 2 and 3 (each within the scatter of the next); then compounds 1 and 4 (each within the scatter of the next).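

Read alone, the methyl on the aromatic carbon is not silent in this assay: hydrogen in its place gives a 3.0-fold higher number from compound 3 to compound 4 (0.48 log units; beyond the scatter), a modest step. The earlier step, a 3.0-fold lower number from compound 1 to compound 2 (0.48 log units; beyond the scatter), changed the group and its place on the ring at once, whereas here the group stays on the same aromatic carbon and only 4-methylphenyl becomes phenyl, so the loss of one heavy atom, with no hydrogen-bond donor or acceptor and no net charge involved, is enough to move the minimum effective dose beyond the scatter. No measurement in hand speaks to the reason for this step.

As far as these compounds go, whether an ethyl group, a fluorine or a hydroxyl on that aromatic carbon would stay with compound 3 or fall with compound 4 remains open, so the methyl result cannot yet be read as a trend across groups at this position. Also open, from the compounds shown here alone, is whether the same step holds in the chlorine-bearing compounds, since this pair carries bromine on the other aryl and a single pair fixes no general rule.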